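The compounds below may be only part of what the source reports. "The series", "measured", "known", "first", "only" and "open" are said of these compounds alone.

Compound 1, `COc1ccc(/C=C/C(=O)c2ccc(NC(=O)CO[N+](=O)[O-])cc2)cc1`: 33%
Compound 2, `CC(=O)c1ccc(OCC(=O)Nc2ccc(C(=O)/C=C/c3ccco3)cc2)cc1`: 28%
Compound 3, `O=C(COCc1c(-c2ccccc2)no[n+]1[O-])Nc1ccc(C(=O)/C=C/c2ccc(Cl)cc2)cc1`: 38%

All three were tested in a functional assay on the whole organism (strain albino) for inhibition, with Rattus norvegicus as the target, read by paw edema, with stated times of 30 min and 1 h, at a dose of 100 mg/kg by the oral route; a lower number here means less inhibition, a higher number more inhibition at the dose given (going by the name of the read-out). Compound 3 gives the highest of the three numbers, with compound 1 nearest and compound 2 furthest, yet both gaps lie within the usual scatter, so no ordering among them can be claimed.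

Compound 4, `O=C(COCc1c(-c2ccccc2)no[n+]1[O-])Nc1ccc(C(=O)/C=C/c2ccco2)cc1`, has not been measured. It differs from compound 3 in one place: furan-2-yl in place of 4-chlorophenyl on a double-bonded chain carbon bound to a double-bonded chain carbon. Going by the values given here, no measured pair differs in just one place, so no measured step guides the expectation. Compound 2 also carries a furan-2-yl group and gives 28%, but it differs from compound 3 elsewhere as well, so its value shows only what that one compound does. The expected step is a number 6 percentage points lower from compound 3 to compound 4 (within the scatter), downward but not beyond the scatter. Compound 4 is expected to give 32%, between 22% and 42%.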

Compound 4, a percentage reported as inhibition, in the whole organism at one dose (the size of the read-out at that dose, not a potency): 30%
For compound 4 the middle estimate is 2 percentage points above the measured one; measured number inside the range.
By their numbers in this assay, from the lowest: compounds 2, 4, 1 and 3 (each within the scatter of the next).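

In this assay, furan-2-yl in place of 4-chlorophenyl on a double-bonded chain carbon bound to a double-bonded chain carbon gives a number 8 percentage points lower from compound 3 to compound 4 (within the scatter). This is the only pair shown that differs in just one place, and it shows that these two rings cannot be told apart at this position at this dose. No measurement shown here accounts for the step. Still open, from the compounds shown here alone, is whether a ring carrying an amine or a carboxylic acid at this position would give a step beyond the scatter.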